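This account rests on a few compounds, and the source may have more. Where it says the series, first, only, none or still open, it means among the compounds named here.

Measured compounds:
- compound 1, `S=C(NCc1ccccc1)N/N=C/c1ccc2ccccc2n1`: 21900 nM in a functional assay on HL-60 cells (Homo sapiens) for antiproliferative activity, read by sulforhodamine B assay, with a stated time of 72 h; a higher number here means a weaker inhibitor, a lower number a stronger inhibitor
- compound 2, `NC(=S)N/N=C/c1ccc2cccnc2n1`: a limit, > 100000 nM
- compound 3, `NC(=S)N/N=C/c1cnc2ccccc2n1`: a limit, > 100000 nM

Compound 1 is the only one of the three whose result is a proper number. For compound 2 the result is a limit of the assay, not a number, and the same holds for compound 3. For the measured compounds named here, both of these sit at the limit of > 100000 nM in this assay, at which 2 of the 3 values shown sit, so compound 1 stands alone as the single measured value on which any comparison can rest, and no step between two measured numbers can be drawn from these three.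

Compound 4, `Fc1ccc(NC(=S)N/N=C/c2ccc3ccccc3n2)cc1`, shares its core with compound 1 and differs from it in a single spot: 4-fluorophenyl in place of benzyl on an amide-type nitrogen. The benzyl group leaves and a 4-fluorophenyl group enters, on the amide-type nitrogen whose other neighbour is the thiocarbonyl carbon.

Going by the values given here, no measured pair in this set shows what such an exchange does, so the direction of the step is uncertain. A change of modest size is expected, not clearly beyond the usual scatter, and compound 1 at 21900 nM is the anchor. Compound 4 is expected to give about 15000 nM, within a range from 5000 nM to 60000 nM. The expected step of a 1.5-fold lower number from compound 1 to compound 4 (0.16 log units; within the scatter) is small and could fall either way.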

Compound 4, half-maximal inhibitory concentration: 17000 nM
The estimate for compound 4 lay 1.1-fold (0.05 log units) below the measured number; the measured number falls inside the stated range.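

In this assay, for the compounds shown here, putting 4-fluorophenyl in place of benzyl on the amide-type nitrogen gives a 1.3-fold lower number from compound 1 to compound 4 (0.11 log units; within the scatter), the first step in this set that joins two measured numbers. At this position, then, the two groups cannot be told apart in this read-out, although the exchange alters what links the ring to the nitrogen and adds a fluorine; each group carries one six-membered aromatic ring of carbon only. Nothing available here explains this result, so the step can only be recorded as it stands.

As far as these compounds go, one exchange between two similar ring-bearing groups says little about how much this position can tolerate overall, and it remains open whether a very different group on the same nitrogen, such as a butyl chain, a morpholine ring or a group carrying a carboxylic acid, would shift the number beyond the scatter. From the compounds shown here alone, it is also open whether a group other than fluorine on the phenyl ring, such as methoxy or nitrile, would give a clearer difference.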